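Hydroxy for Ethyl on the Chain: Expected Recovery of Inhibition

The compounds below may be only part of what the source reports. "The series", "measured", "known", "first", "only" and "open" are said of these compounds alone.

Compound 1 `C=CCc1cc(C(C)=O)c(O)cc1OCCCCC#N`: 92%
Compound 2 `C=CCc1cc(C(C)=O)c(O)cc1OCCCCCC`: 50%

In an assay on isolated protein for inhibition of leukotriene B4 receptor 1 (Homo sapiens), tested at 10 uM (on this read-out lower numbers stand for less inhibition and higher numbers for more inhibition at the one concentration tested (going by the name of the read-out)), compound 2 gives 50%, the lower of the two measured numbers; the step of a number 42 percentage points lower from compound 1 to compound 2 (beyond the scatter) is large. Compound 3 `C=CCc1cc(C(C)=O)c(O)cc1OCCCCO` differs from compound 2 by hydroxy in place of ethyl on a saturated chain carbon, four bonds along the chain from an oxygen on an aromatic ring. Within the data shown here, the only measured step that bears on this place is a number 42 percentage points lower from compound 1 to compound 2 (beyond the scatter), in which ethyl replaced cyano. Hydroxy, like cyano, brings a hydrogen-bond acceptor back to that chain carbon, so a rise of roughly that size is expected, a number 30 percentage points higher from compound 2 to compound 3 (beyond the scatter). Compound 3 is therefore estimated at 80% in this assay, with a range from 60% to 95%.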

Compound 3, a percentage reported as inhibition, at one concentration (the size of the read-out at that concentration, not a potency): 48%
Compound 3: middle estimate off by 32 percentage points, on the high side; measured number below the stated range.
By their numbers in this assay, from the lowest: compounds 3 and 2 (each within the scatter of the next); then compound 1.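

In this assay, hydroxy in place of cyano gives a number 44 percentage points lower from compound 1 to compound 3 (beyond the scatter), whereas hydroxy in place of ethyl gives a number 2 percentage points lower from compound 2 to compound 3 (within the scatter). On this chain carbon, then, the hydrogen-bond donor and acceptor that hydroxy brings in place of ethyl go with no change beyond the scatter, and of the three groups only cyano stands apart. No available evidence accounts for this result. On these data alone, whether an amine, a carboxylic acid or a longer chain ending in a nitrile would stand with cyano or with hydroxy and ethyl remains open.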